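Ring amine in place of arylamine: expectation for compound 4

The source may hold more compounds than are shown below. What is called first, only, known or untested is meant among the compounds shown, and "the series" means these compounds.

Compound 2 `Cc1ccc(Nc2nc(C(F)(F)F)ccc2CNC(=O)C(C)c2ccc(NS(C)(=O)=O)c(F)c2)cc1C` gives the highest number of the three measured in a functional assay on CHO-K1 cells for antagonist activity at transient receptor potential cation channel subfamily V member 1 (Homo sapiens), read by FLIPR (a lower number here means a stronger inhibitor, a higher number a weaker inhibitor), at 1160 nM. Compound 1 `CC(C(=O)NCc1ccc(C(F)(F)F)nc1NC1CCCCC1)c1ccc(NS(C)(=O)=O)c(F)c1` gives 260 nM in this assay, and compound 3 `CCCCN(C)c1nc(C(F)(F)F)ccc1CNC(=O)C(C)c1ccc(NS(C)(=O)=O)c(F)c1` gives 21.3 nM. The three differ from one another at a single position on the shared core, and the steps are a 4.5-fold higher number from compound 1 to compound 2 (0.65 log units; beyond the scatter), a 12-fold lower number from compound 1 to compound 3 (1.09 log units; beyond the scatter) and a 54-fold lower number from compound 2 to compound 3 (1.74 log units; beyond the scatter). Both moves away from the (3,4-dimethylphenyl)amino group of compound 2 lower the number, and the move to the tertiary amine of compound 3 lowers it most.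

Compound 4 `CC(C(=O)NCc1ccc(C(F)(F)F)nc1N1CCCC1)c1ccc(NS(C)(=O)=O)c(F)c1` is compound 2 with one change: pyrrolidin-1-yl in place of (3,4-dimethylphenyl)amino on an aromatic carbon. The step from compound 2 to compound 3 bears most directly on it, since the same group leaves and a group with no hydrogen-bond donor enters in both cases; the step from compound 1 to compound 3 points the same way. A large drop in this assay is therefore expected, though somewhat short of the drop seen with compound 3. Pyrrolidin-1-yl is a different group from butyl(methyl)amino, and its effect has not been measured here. The expected step is a 29-fold lower number from compound 2 to compound 4 (1.46 log units; beyond the scatter). Compound 4 is estimated at 40 nM, with a range from 10 nM to 160 nM.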

Compound 4, half-maximal inhibitory concentration: 211 nM
Compound 4: the middle estimate sits 5.3-fold (0.72 log units) below what was measured; the whole stated range lies below it.
By their numbers in this assay, from the lowest: compound 3; then compounds 4 and 1 (each within the scatter of the next); then compound 2.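

In this assay, having 0 hydrogen-bond donors in the group on this aromatic carbon does not by itself bring a number close to that of compound 3: pyrrolidin-1-yl gives a 5.5-fold lower number from compound 2 to compound 4 (0.74 log units; beyond the scatter), while closing the amine into this ring in place of the open butyl(methyl)amino gives a 9.9-fold higher number from compound 3 to compound 4 (1.00 log units; beyond the scatter). The step of a 1.2-fold lower number from compound 1 to compound 4 (0.09 log units; within the scatter) leaves pyrrolidin-1-yl and cyclohexylamino indistinguishable at this position, whereas the (3,4-dimethylphenyl)amino group of compound 2 stays clearly apart from both. Among the four compounds, the open tertiary amine of compound 3 therefore stands alone, and no measurement is available to account for its gap to the pyrrolidin-1-yl group.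

Whether that gap follows the length of the butyl chain or the open form of the amine remains unsettled, and a dimethylamino or dipropylamino group at this position would help separate the two. Piperidin-1-yl or morpholin-4-yl would show how far the number at this position moves with the size and atoms of the ring.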